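Chain extension between two assay limits

The compounds below may be only part of what the source reports. "The series", "measured", "known", "first", "only" and "open" are said of these compounds alone.

Compound 1 `CC1OC(OC2CCCCC2OCCCCCC(C(=O)O)C(=O)O)C(O)C(O)C1O`: > 5000000 nM
Compound 2 `CC1OC(OC2CCCCC2OCCCCCCCC(C(=O)O)C(=O)O)C(O)C(O)C1O`: > 5000000 nM

In a functional assay on HL-60 cells (Homo sapiens) for inhibition (a higher number here means a weaker inhibitor, a lower number a stronger inhibitor), compound 1 gives > 5000000 nM, which is a limit of the assay and not a number. Compound 2 likewise gives > 5000000 nM, again a limit. Compound 2 thus stands at the limit of > 5000000 nM in this assay, at which 2 of the 2 values shown sit. The step that the two limits leave unreadable from compound 1 to compound 2 is therefore unreadable in size. Compound 3 `CC1OC(OC2CCCCC2OCCCCCCCCCCC(C(=O)O)C(=O)O)C(O)C(O)C1O` differs from compound 2 in that (4,4-dicarboxybutyl in place of dicarboxymethyl on a saturated chain carbon, seven bonds along the chain from an oxygen on a saturated carbon). Among the measured compounds shown here, the single measured step, being unreadable, gives no direction, so no step beyond the scatter is expected in this assay. Compound 3 is expected to give 5000000 nM, with a range from 1000000 nM to 20000000 nM. The expected step of a number no higher from compound 2 to compound 3 (the limit leaves the size open) is estimated to be none beyond the scatter.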

Compound 3, half-maximal inhibitory concentration: > 5000000 nM
Compound 3: no number, only a limit; the forecaster's own chance of this, stated with the estimate: 90%; the middle value sits exactly at the limit.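

No new step can be read: compound 2 and compound 3 each give only a limit in this assay, not a number: the limit of > 5000000 nM in this assay, at which 3 of the 3 values shown sit.

What compound 1, compound 2 and compound 3 leave open is whether chain length has any bearing on inhibition.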